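Working notes: 1,3-oxazol-2-yl for pyridazin-3-yl in compound 4

This account rests on a few compounds, and the source may have more. Where it says the series, first, only, none or still open, it means among the compounds named here.

The series shares one core carrying a chlorine and a propanoic acid chain; the variable position is the aromatic carbon bearing the ether or alkyl group. Compound 1 `COCCOc1cc2oc(=O)n(CCC(=O)O)c2cc1Cl` is the weakest anchor: in an assay on HEK293 cells for inhibition of kynurenine 3-monooxygenase (Homo sapiens), read by LC-MS, with a stated time of 20 h (on this read-out lower numbers stand for stronger inhibition and higher numbers for weaker inhibition), compound 1 gives 50100 nM. Compound 2 `CCc1cc2oc(=O)n(CCC(=O)O)c2cc1Cl` gives 316 nM in this assay, and compound 3 `C[C@@H](Oc1cc2oc(=O)n(CCC(=O)O)c2cc1Cl)c1cccnn1` gives 631 nM. The two steps from compound 1 are both large: a 160-fold lower number from compound 1 to compound 2 (2.20 log units; beyond the scatter) and a 79-fold lower number from compound 1 to compound 3 (1.90 log units; beyond the scatter). Compound 3 therefore stands second highest of the three numbers; its value sits within the scatter of the value of compound 2 and far below that of compound 1.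

Compound 4 `C[C@@H](Oc1cc2oc(=O)n(CCC(=O)O)c2cc1Cl)c1ncco1` differs from compound 3 only by 1,3-oxazol-2-yl in place of pyridazin-3-yl on a saturated chain carbon bound to an oxygen on an aromatic ring and a saturated chain carbon. Among the compounds with values here, no measured step alters the ring on that chain carbon: the step from compound 1 to compound 3 installs the whole side chain at once, and the step from compound 1 to compound 2 concerns an unrelated substituent. Nothing here shows how swapping one two-heteroatom aromatic ring for another moves the number, so the expectation is a step of a 1.3-fold higher number from compound 3 to compound 4 (0.10 log units; within the scatter), within the scatter. Compound 4 is estimated at 800 nM in this assay, between 250 nM and 3000 nM.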

Compound 4, half-maximal inhibitory concentration: 7940 nM
For compound 4 the middle estimate is 9.9-fold (1.00 log units) below the measured one; measured number above the stated range.
By their numbers in this assay, from the lowest: compounds 2 and 3 (each within the scatter of the next); then compound 4; then compound 1.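

The ring on the saturated chain carbon bound to an oxygen on an aromatic ring clearly affects the read-out in this assay: a 13-fold higher number from compound 3 to compound 4 (1.10 log units; beyond the scatter), even though pyridazin-3-yl and 1,3-oxazol-2-yl have the same counts of hydrogen-bond donors and acceptors and neither carries a net charge. The side chain with 1,3-oxazol-2-yl still gives a lower number than 2-methoxyethoxy, with a 6.3-fold lower number from compound 1 to compound 4 (0.80 log units; beyond the scatter), but a higher number than ethyl, with a 25-fold higher number from compound 2 to compound 4 (1.40 log units; beyond the scatter), so the large gain seen with the pyridazin-3-yl side chain is only partly kept with this ring. No supporting measurement bears on the reason for this loss.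

With one pair of rings, the change from a six-membered to a five-membered ring cannot be separated from the change in ring atoms, as the two differ together here. Pyridin-2-yl and 1,3-thiazol-2-yl on the same chain carbon lie outside the compounds shown, so it remains open whether the step belongs to 1,3-oxazol-2-yl alone or extends to other aromatic rings at this place.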